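This account rests on a few compounds, and the source may have more. Where it says the series, first, only, none or still open, it means among the compounds named here.

Compound 1 `N#CC1=C(N)Oc2c(c3nc4ccccc4nc3c3ccccc23)C12C(=O)N(Cc1cnnn1-c1ccc(Cl)cc1)c1ccccc12`: > 50000 nM
Compound 2 `COc1ccc(-n2nncc2CN2C(=O)C3(C(C#N)=C(N)Oc4c3c3nc5ccccc5nc3c3ccccc43)c3ccccc32)cc1`: > 50000 nM
Compound 3 `N#CC1=C(N)Oc2c(N)cc3nc4ccccc4nc3c2C12C(=O)N(Cc1cnnn1-c1ccc(Cl)cc1)c1ccccc12`: > 50000 nM

In an ADME assay on HUVEC cells (Homo sapiens) for antiproliferative activity, read by MTT assay, with a stated time of 48 h (a lower number here means a stronger inhibitor, a higher number a weaker inhibitor), compound 1 gives > 50000 nM, a limit of the assay rather than a number. Compound 2 likewise gives > 50000 nM, again a limit. Compound 3 stands at > 50000 nM, also a limit. Among the compounds with values here, the only one-place step, a step that the two limits leave unreadable from compound 1 to compound 2, cannot be sized because the limit of > 50000 nM in this assay, at which 3 of the 3 values shown sit, holds both of its ends. Compound 4 `N#CC1=C(N)Oc2c(N)cc3nc4ccccc4nc3c2C12C(=O)N(Cc1cnnn1-c1ccc(F)c(Cl)c1)c1ccccc12` differs from compound 3 by 3-chloro-4-fluorophenyl in place of 4-chlorophenyl on an aromatic nitrogen. Within the data shown here, no readable step touches this change; the single comparable step is unreadable. Compound 4 is therefore expected to remain at the limit, with a number no higher from compound 3 to compound 4 (the limit leaves the size open) expected to show no step beyond the scatter. Compound 4 is estimated at 50000 nM, between 20000 nM and 120000 nM.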

Compound 4, half-maximal inhibitory concentration: > 50000 nM
Compound 4: a limit, no number; the forecaster's own chance of this, stated with the estimate: 85%; the middle value lies on the limit itself.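

Compound 4 gives > 50000 nM, a limit and not a number, so no step can be read from compound 3 to compound 4: the limit of > 50000 nM in this assay, at which 4 of the 4 values shown sit.

The compounds shown leave open how 3-chloro-4-fluorophenyl and 4-chlorophenyl compare, and what the true value of any compound is.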